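A few compounds are considered here, and "the series" means these few. Any claim that something is new, unique, unknown or untested is made for them only; others in the source may bear on it.

Of the compounds shown here, three with a shared core have been measured in a functional assay on HUVEC cells (Homo sapiens) for inhibition, tested at 5 ug/mL; on this read-out lower numbers stand for a weaker effect and higher numbers for a stronger effect at the one concentration tested. Compound 1 `COc1cc(/C=C/C(=O)c2cccc(NC(=O)c3c(Cl)cccc3Cl)c2)ccc1O` carries a 2,6-dichlorophenyl group on the carbonyl carbon of its amide and gives 88%. Compound 2 `COc1cc(/C=C/C(=O)c2cccc(NC(=O)c3cccs3)c2)ccc1O` carries a thiophen-2-yl group there and gives 80%; the step of a number 8 percentage points lower from compound 1 to compound 2 (within the scatter) lies within the scatter. Compound 3 `COc1cc(/C=C/C(=O)c2cccc(NC(=O)C(C)C)c2)ccc1O` carries an isopropyl group in that place and gives 51%, which is the lowest of the three numbers: the steps of a number 37 percentage points lower from compound 1 to compound 3 (beyond the scatter) and a number 29 percentage points lower from compound 2 to compound 3 (beyond the scatter) both lie beyond the scatter, so the ring-bearing compounds are clearly stronger than compound 3 in this assay.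

Compound 4 `CCCC(=O)Nc1cccc(C(=O)/C=C/c2ccc(O)c(OC)c2)c1` differs from compound 3 in one place: propyl in place of isopropyl on a carbonyl carbon. The two measured steps that reach compound 3 both exchange a ring for a chain, so they are of a different kind from this change, which keeps a three-carbon chain and only rearranges it. For the measured compounds named here, no measured step compares two such chains, so nothing in the data points to a shift in either direction. A step not beyond the scatter is therefore expected for compound 4, that is a number 1 percentage points lower from compound 3 to compound 4 (within the scatter). Compound 4 is estimated at 50%, in a range of 35% to 65%.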

Compound 4, a percentage reported as inhibition, at one concentration (the size of the read-out at that concentration, not a potency): 57%
Compound 4: middle estimate off by 7 percentage points, on the low side; measured number inside the range.
By their numbers in this assay, from the lowest: compounds 3 and 4 (each within the scatter of the next); then compounds 2 and 1 (each within the scatter of the next).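

In this assay, moving from isopropyl to propyl on the carbonyl carbon gives a number 6 percentage points higher from compound 3 to compound 4 (within the scatter) and so does not separate the branched chain from the straight one at this position. The earlier compounds shown here did not offer this comparison, and none of them paired two chains. The gap between rings and chains also survives this change of chain shape, with a number 23 percentage points lower from compound 2 to compound 4 (beyond the scatter) and a number 31 percentage points lower from compound 1 to compound 4 (beyond the scatter) showing that the lower numbers of compound 3 are shared by a second chain and do not belong to isopropyl alone. No measurement at hand explains why the ring-bearing compounds give the higher numbers.

The compounds shown leave open whether the chain result holds for a shorter group such as methyl or a longer chain such as pentyl, and whether a chain ending in an amine or a carboxylic acid would stay with compound 3 and compound 4 or move toward compound 1. They also leave open whether a plain phenyl ring, without the two chlorines, would match the 2,6-dichlorophenyl and thiophen-2-yl groups.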